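The source may hold more compounds than are shown below. What is called first, only, known or untested is meant among the compounds shown, and "the series" means these compounds.

Compound 2 `CC[C@H]1CN(c2ncc(C(=O)NC)nc2C)CCN1C1CCN(C(=O)c2ccc(Cl)cc2)CC1` gives the lowest of the two numbers measured in an in vitro assay on BaF3 cells for displacement of a labelled ligand from C-X-C chemokine receptor type 3 (Homo sapiens) (on this read-out higher numbers stand for weaker inhibition and lower numbers for stronger inhibition), at 3.6 nM; compound 1 `CC[C@H]1CN(c2ncc(C(N)=O)nc2C)CCN1C1CCN(C(=O)c2ccc(Cl)cc2)CC1` gives 18 nM. For the measured compounds named here, the only measured step, a 5.0-fold lower number from compound 1 to compound 2 (0.70 log units; beyond the scatter), shows that growing the amide substituent helped. Compound 3 `CC[C@H]1CN(c2ncc(C(=O)NC3CC3)nc2C)CCN1C1CCN(C(=O)c2ccc(Cl)cc2)CC1` carries the next enlargement, (cyclopropyl in place of methyl on an amide-type nitrogen). Going by the values given here, no measured step covers methyl to cyclopropyl, so the direction is uncertain, and only a step of modest size in this assay is expected, as a 1.2-fold lower number from compound 2 to compound 3 (0.08 log units; within the scatter). Compound 3 is therefore estimated at 3 nM, within 1 nM to 12 nM.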

Compound 3, half-maximal inhibitory concentration: 1.1 nM
Compound 3: middle estimate off by 2.7-fold (0.44 log units), on the high side, within the range that was stated.
By their numbers in this assay, from the lowest: compound 3; then compound 2; then compound 1.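

In this assay the amide nitrogen keeps responding after methyl: cyclopropyl gives a 3.3-fold lower number from compound 2 to compound 3 (0.51 log units; beyond the scatter) and so extends the gain that methyl began. Taken from the amide with no substituent, the change gives a 16-fold lower number from compound 1 to compound 3 (1.21 log units; beyond the scatter) in all, and across these three compounds the number falls as the group on this nitrogen grows, with none going against that order. No evidence here explains this result.

As far as these compounds go, whether the order continues with cyclobutyl or a longer chain such as propyl stays open. Also open, from the compounds shown here alone, is how a hydroxyethyl group or an amine-bearing chain on this nitrogen would fare.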